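This account rests on a few compounds, and the source may have more. Where it says the series, first, only, none or still open, it means among the compounds named here.

Compound 1 `O=C(/C=C/c1ccccc1)Nc1cc2c(Nc3ccc(Cl)c(Cl)c3)ncnc2s1` and compound 3 `O=C(/C=C/c1ccccc1)Nc1cc2c(Nc3cc(Cl)cc(Cl)c3)ncnc2s1` are built on one core, while compound 2 `O=C(/C=C/c1ccccc1)Nc1cc2ncnc(Nc3cc(Cl)cc(Cl)c3)c2s1` and compound 4 `O=C(/C=C/c1ccccc1)Nc1cc2ncnc(Nc3ccc(Cl)c(Cl)c3)c2s1` are built on another; the difference between the two cores is not broken down here. In a functional assay on MDA-MB-231 cells (Homo sapiens) for antiproliferative activity, read by MTT assay, with a stated time of 48 h (a higher number here means a weaker inhibitor, a lower number a stronger inhibitor), compound 1 gives 4400 nM. In this assay compound 3 gives 11500 nM, and compound 2 gives 1000 nM, the lowest of the three numbers. Within the first core, the change 3,4-dichlorophenyl in place of 3,5-dichlorophenyl on a nitrogen on an aromatic ring made a step of a 2.6-fold lower number from compound 3 to compound 1 (0.42 log units; beyond the scatter). The same change, (3,4-dichlorophenyl in place of 3,5-dichlorophenyl on a nitrogen on an aromatic ring), carries compound 2 to compound 4 at a place described in identical words. A step of like size in this assay is expected, so that compound 4 is estimated to sit at a 2.5-fold lower number from compound 2 to compound 4 (0.40 log units; beyond the scatter), an expectation that rests only on the step of a 2.6-fold lower number from compound 3 to compound 1 (0.42 log units; beyond the scatter). Compound 4 is therefore expected to give 400 nM, with a likely range from 150 nM to 1500 nM.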

Compound 4, half-maximal inhibitory concentration: 2410 nM
Compound 4: middle estimate off by 6.0-fold (0.78 log units), on the low side; the measured number lies above the stated range.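

On the core of compound 2, 3,4-dichlorophenyl in place of 3,5-dichlorophenyl gave, in this assay, a step of a 2.4-fold higher number from compound 2 to compound 4 (0.38 log units; beyond the scatter). Set beside the step on the core of compound 1, the direction is reversed, so this change did not carry over from one core to the other: the same change on two cores in this assay, a 2.6-fold lower number (0.42 log units; beyond the scatter) from compound 3 to compound 1 and a 2.4-fold higher number (0.38 log units; beyond the scatter) from compound 2 to compound 4, 6.3-fold (0.80 log units) apart, beyond the scatter of two such steps. With one pair on each core, this shows that the outcome of this change depended on the core in these four compounds, but it does not show why, nor whether other changes at this place behave the same way.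

The compounds shown leave open whether a phenyl ring carrying a single chlorine or a methoxy group on that nitrogen would also respond differently on the two cores.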